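The source may report more compounds than this note shows. Statements on the series, on what has been measured and on what is new or still open speak of the compounds shown alone.

In a functional assay on HCT-8 cells (Homo sapiens) for antiproliferative activity, read by MTT assay, with a stated time of 48 h (a higher number here means a weaker inhibitor, a lower number a stronger inhibitor), compound 1 (`COc1ccc(C(=O)c2cc(OC)c(OC)c(OC)c2)c(NC(=O)CO)c1`) gives 120 nM and compound 2 (`COc1ccc(C(=O)c2cc(OC)c(OC)c(OC)c2)c(NC(=O)CN(C)C)c1`) gives 790 nM as the higher of the two numbers. Compound 3 (`COc1ccc(C(=O)c2cc(OC)c(OC)c(OC)c2)c(NC(=O)CN)c1`) carries amino in place of dimethylamino on a saturated chain carbon bound to a carbonyl carbon. Going by the values given here, the one measured step bearing on this is a 6.6-fold higher number from compound 1 to compound 2 (0.82 log units; beyond the scatter) where dimethylamino replaced hydroxy. That single step is thin evidence, but it suggests that losing dimethylamino could recover part of the gap, so a modest fall is expected in this assay and not a full return. The expected change is a 2.6-fold lower number from compound 2 to compound 3 (0.42 log units; beyond the scatter) as an estimate only. For compound 3 the estimated value is 300 nM (range 90 nM to 1000 nM).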

Compound 3, half-maximal inhibitory concentration: 330 nM
Compound 3: middle estimate off by 1.1-fold (0.04 log units), on the low side; measured number inside the range.
By their numbers in this assay, from the lowest: compound 1; then compound 3; then compound 2.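

In this assay, amino in place of dimethylamino gives a 2.4-fold lower number from compound 2 to compound 3 (0.38 log units; beyond the scatter), so a nitrogen group at this position need not cost as much as dimethylamino did. The recovery is only partial, since amino in place of hydroxy still gives a 2.8-fold higher number from compound 1 to compound 3 (0.44 log units; beyond the scatter), and on this saturated chain carbon bound to a carbonyl carbon, hydroxy keeps the lowest number of the three groups. Nothing measured here explains this order. Going by these compounds, whether methoxy, methylamino or a longer chain ending in hydroxy would match hydroxy remains open.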